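Benzyloxy for Amino at the Sugar Ring: an Expectation

The source may report more compounds than this note shows. Statements on the series, on what has been measured and on what is new or still open speak of the compounds shown alone.

Measured so far:
compound 1 `Nc1cn([C@H]2C[C@H](O)[C@@H](CO)O2)c(=O)[nH]c1=O` — 72000 nM
compound 2 `Cc1cn([C@H]2C[C@H](N)[C@@H](CO)O2)c(=O)[nH]c1=O` — 2600000 nM

In an assay on isolated protein for inhibition of thymidine kinase 2 (Rattus norvegicus) (a lower number here means a stronger inhibitor, a higher number a weaker inhibitor), compound 2 gives 2600000 nM, the highest of the two numbers, while compound 1 gives 72000 nM; no step between them is worked out, so only the two values themselves are shown. Compound 3 `Cc1cn([C@H]2C[C@H](OCc3ccccc3)[C@@H](CO)O2)c(=O)[nH]c1=O` has not been measured. It differs from compound 2 in one place: benzyloxy in place of amino on a saturated ring carbon. Among the compounds with values here, no step is known for such a change here. Compound 3 is expected to be a somewhat stronger inhibitor than compound 2, a moderate step of an 8.7-fold lower number from compound 2 to compound 3 (0.94 log units; beyond the scatter) with wide uncertainty. Compound 3 is estimated at 300000 nM, within 30000 nM to 3000000 nM.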

Compound 3, inhibition constant: 8000 nM
For compound 3 the middle estimate is 38-fold (1.57 log units) above the measured one; measured number below the stated range.
By their numbers in this assay, from the lowest: compound 3; then compound 1; then compound 2.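

In this assay, benzyloxy in place of amino on this saturated ring carbon gives a 330-fold lower number from compound 2 to compound 3 (2.51 log units; beyond the scatter), a large step beyond the scatter. What sits at this position therefore matters greatly, and a much bigger group carrying an aromatic ring comes with a stronger inhibitor, not a weaker one. Nothing at hand explains the gain.

From the compounds shown here alone, the change swaps several features at once, so it remains open which of them carries the step. Methoxy or a longer phenylethoxy chain at this carbon would help separate them.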